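Urea series: aryl change on the amide-type nitrogen

A few compounds are considered here, and "the series" means these few. Any claim that something is new, unique, unknown or untested is made for them only; others in the source may bear on it.

Compound 1 `CCN1CCc2c(sc(NC(=O)Nc3ccc(Br)cc3)c2C(N)=O)C1` serves as the reference point. In a functional assay (strain AB) with Danio rerio as the target, read by microscopy, with a stated time of 1 h (on this read-out higher numbers stand for an effect only at larger amounts of compound and lower numbers for an effect already at smaller amounts), compound 1 gives 3130 nM, the smaller of the two numbers recorded in the set. Compound 3 `CCN1CCc2sc(NC(=O)Nc3ccc(Cl)cc3)c(C(N)=O)c2CC1` in this assay gives 5800 nM; the gap to compound 1 lies within the scatter, so the two cannot be ordered. Compound 2 `CCC(O)c1cc2c(cc1NC(=O)Nc1ccc(Cl)cc1)OCCO2` in this assay gives only a limit, > 25000 nM. For compound 2 the reading is the limit of > 25000 nM in this assay, at which 1 of the 3 values shown sits, and not a number.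

Compound 4 `CCN1CCc2c(sc(NC(=O)Nc3cccc(Cl)c3Cl)c2C(N)=O)C1` has not been measured in this assay. Relative to compound 1 the change is 2,3-dichlorophenyl in place of 4-bromophenyl on an amide-type nitrogen. Going by the values given here, no measured pair in the set shows a change of this kind, so it has no precedent here; the shared core and the amide-type nitrogen remain unchanged. The expected step of a 1.3-fold higher number from compound 1 to compound 4 (0.11 log units; within the scatter) is small, within the scatter, and its direction is open. Compound 4 is estimated at 4000 nM in this assay, with a range of 1500 nM to 12000 nM.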

Compound 4, half-maximal effective concentration: 17400 nM
Beside the measured number, compound 4's estimate is 4.4-fold (0.64 log units) below it, outside the stated range (above it).
By their numbers in this assay, from the lowest: compounds 1 and 3 (each within the scatter of the next); then compound 4. At a limit, above all of these: compound 2.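

In this assay the place on the amide-type nitrogen proves sensitive to the choice of aryl group: 2,3-dichlorophenyl in place of 4-bromophenyl gives a 5.6-fold higher number from compound 1 to compound 4 (0.75 log units; beyond the scatter). Going by these compounds alone, this is the only step in the set between compounds that differ in one place, so it gives the series its first direct reading of this position, and with the shared core held constant, the change of aryl group alone moves the number beyond the scatter. Nothing measured on these compounds bears on why the step occurs.

Open, from the compounds shown here alone, is whether both chlorines are needed for the step, or whether 2-chlorophenyl or 3-chlorophenyl on the same nitrogen would read like compound 1 or like compound 4. Also open, going by these compounds, is how a pyridyl ring or 4-methoxyphenyl would read at this place.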